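The source may report more compounds than this note shows. Statements on the series, on what has been measured and on what is new or still open speak of the compounds shown alone.

Compound 1, `Nc1ccnc(Nc2cc(Cl)cc(Cl)c2)c1`. In an assay on cells for inhibition of S-adenosylmethionine decarboxylase proenzyme (Homo sapiens), read by mass spectrometry, at pH 7.2 (on this read-out higher numbers stand for weaker inhibition and lower numbers for stronger inhibition), compound 1 gives only a limit, > 180000 nM.
Compound 2, `Cc1cc(N)cc(Nc2cc(Cl)cc(Cl)c2)n1`. In this assay compound 2 gives only a limit, > 180000 nM.
Compound 3, `Cc1cc(Nc2cc(Cl)cc(Cl)c2)ncn1`. In this assay compound 3 gives only a limit, > 180000 nM.

Compound 3 therefore stands at a limit of this assay, as the limit of > 180000 nM in this assay, at which 3 of the 3 values shown sit, records, and not at a number. Within the data shown here, the single step between measured compounds, a step that the two limits leave unreadable from compound 1 to compound 2, is left unreadable by the two limits. Compound 4, `CNc1nc(C)cc(Nc2cc(Cl)cc(Cl)c2)n1`, differs from compound 3 by methylamino in place of hydrogen on an aromatic carbon. Among the measured compounds shown here, no measured step bears on this change, and the three limits give no direction to expect in this assay. The expected step is an at least 1.2-fold lower number from compound 3 to compound 4 (0.07 log units; that floor lies within the scatter), nothing beyond the scatter. Compound 4 is therefore expected near 150000 nM, within 20000 nM to 1000000 nM, most likely reported again only as a limit.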

Compound 4, half-maximal inhibitory concentration: > 63000 nM
Compound 4: a limit, no number; the forecaster's own chance of this, stated with the estimate: 65%; the middle value does not contradict the limit.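

In this assay compound 4 gives only a limit, > 63000 nM. Among these compounds, compound 3 also gives only a limit, > 180000 nM, so no step from compound 3 to compound 4 can be read. The compounds shown leave open whether methylamino in place of hydrogen on an aromatic carbon changes inhibition at all.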